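This account rests on a few compounds, and the source may have more. Where it says the series, first, only, none or still open, it means among the compounds named here.

Two close relatives have been measured so far. In a functional assay on U-251 cells (Homo sapiens) for cytotoxicity (a higher number here means a weaker inhibitor of growth, a lower number a stronger inhibitor of growth), compound 1 (`COc1ccc(C2=C(c3ccc(SC)cc3)CC3CCCN3C2=O)cc1O`) gives 5000 nM and compound 2 (`COc1ccc(C2=C(c3ccc(SC)cc3)CC3CCCN3C2=O)cc1`) gives 2000 nM as the lower of the two numbers. Within the data shown here, the only measured step is a 2.5-fold lower number from compound 1 to compound 2 (0.40 log units; beyond the scatter) with hydrogen in place of hydroxy on an aromatic carbon, a modest change in growth inhibition.

Compound 3 (`CSc1ccc(C2=C(c3ccc(Br)cc3)C(=O)N3CCCC3C2)cc1`) has yet to be measured. It keeps the shared core of compound 2 but has bromo in place of methoxy on an aromatic carbon, para to a large group (bromo in place of methoxy on an aromatic carbon), so 4-methoxyphenyl becomes 4-bromophenyl.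

Among the measured compounds shown here, no measured compound carries bromo, and none lacks the methoxy, so the one measured step concerns a different group and gives no direction for this swap. It serves only as a rough guide to size, showing that a single small substitution moved the number modestly. The expected change is therefore a 1.3-fold higher number from compound 2 to compound 3 (0.10 log units; within the scatter) and this estimated step stays within the scatter, though a modest move either way remains possible. For compound 3 the estimated value is 2500 nM with an expected range from 700 nM to 9000 nM in this wide estimate.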

Compound 3, concentration for 50% growth inhibition: 7000 nM
The estimate for compound 3 lay 2.8-fold (0.45 log units) below the measured number; measured number inside the range.
By their numbers in this assay, from the lowest: compound 2; then compounds 1 and 3 (each within the scatter of the next).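

In this assay, among these compounds, the aromatic carbon para to a large group proves able to shift growth inhibition: bromo in place of methoxy gives a 3.5-fold higher number from compound 2 to compound 3 (0.54 log units; beyond the scatter) as a modest move, and this is the first measured information on that site. The same compound 3 compared with its hydroxy-bearing relative, with 4-bromophenyl in place of 3-hydroxy-4-methoxyphenyl, gives a 1.4-fold higher number from compound 1 to compound 3 (0.15 log units; within the scatter) and so cannot be told apart from compound 1 here, even though the two rings differ in more than one place. Among the compounds shown here, nothing measured so far accounts for either result.

The compounds shown leave open how an amine, a carboxylic acid or a longer chain such as ethoxy would behave at this position, as only methoxy and bromo appear there so far. They also leave open whether bromo in place of methoxy would move the number in the same direction and by a similar amount on a ring that keeps the hydroxy of compound 1.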